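The source may report more compounds than this note shows. Statements on the series, on what has been measured and on what is new or still open speak of the compounds shown alone.

Notes on an ADME assay on S9 fraction from liver (Rattus norvegicus) for metabolic stability, read by LC-MS, using NADPH, with a stated time of 30 min; a higher number here means that more of the compound is left, a lower number that less of the compound is left. Compound 1 `CCCCCCCCc1ccc(OCC(=O)Cn2ncnn2)cc1` gives < 5%, which is a limit of the assay. Compound 2 `CCCCCCCCc1ccc(OCC(=O)Cn2nnc(-c3ccc(Cl)cc3)n2)cc1` reads 74%. Compound 3 `CCCCCCCCc1ccc(OCC(=O)Cn2nnc(-c3ccc(S(=O)(=O)N(C)C)cc3)n2)cc1` reads 65%, level with compound 2 given the step of a number 9 percentage points lower from compound 2 to compound 3 (within the scatter).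

Compound 4 `CCCCCCCCc1ccc(OCC(=O)Cn2nnc(C(=O)O)n2)cc1` carries carboxy in place of 4-(dimethylsulfamoyl)phenyl on an aromatic carbon. Two large steps bear on this: a number at least 69 percentage points higher from compound 1 to compound 2 (beyond the scatter) with 4-chlorophenyl, and a number at least 60 percentage points higher from compound 1 to compound 3 (beyond the scatter) with 4-(dimethylsulfamoyl)phenyl. Among the measured compounds shown here, both added a six-membered aromatic ring, which compound 4 lacks, but no measured step covers carboxy. A sizeable fall is therefore expected in this assay, estimated as a number 30 percentage points lower from compound 3 to compound 4 (beyond the scatter). For compound 4 the estimated value is 35%, with an expected range of 8% to 70%.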

Compound 4, percent of the compound remaining: 52%
Compound 4: middle estimate off by 17 percentage points, on the low side, and the stated range covers the measured number.
By their numbers in this assay, from the lowest: compound 4; then compounds 3 and 2 (each within the scatter of the next). At a limit, below all of these: compound 1.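

In this assay, a substituent on this aromatic carbon of the five-membered ring with 4 nitrogen need not contain a six-membered aromatic ring to give a large gain over hydrogen: a number at least 47 percentage points higher from compound 1 to compound 4 (beyond the scatter). The value of compound 1 is a limit, so this step is only a bound: the limit of < 5% in this assay, at which 1 of the 4 values shown sits. Carboxy still gives modest losses against both aryl groups, with a number 13 percentage points lower from compound 3 to compound 4 (beyond the scatter) and a number 22 percentage points lower from compound 2 to compound 4 (beyond the scatter).

On these data alone, whether these losses follow from removing the six-membered aromatic ring or from introducing carboxy remains open. A methyl ester or a primary amide at this position would help separate the two.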